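The source may hold more compounds than are shown below. What is called first, only, known or untested is meant among the compounds shown, and "the series" means these compounds.

In a functional assay on HeLa cells (Homo sapiens) for inhibition, with a stated time of 72 h (a lower number here means that less compound is needed, a higher number that more compound is needed for the effect), compound 1 (`COc1cc(CNCCSc2nnnn2C)ccc1OCc1ccc(Cl)nc1`) gives 86000 nM and compound 3 (`COc1cc(CNc2nc[nH]n2)ccc1OCc1ccc(Cl)nc1`) gives 69000 nM. These two numbers lie within the scatter of each other, so compound 3 stands level with compound 1. Compound 2 (`COc1cc(CNCc2ccc(C(=O)O)cc2)ccc1OCc1ccc(Cl)nc1`) has no number, only the entry "nd(insoluble)" (no result reported). Compound 4 (`COc1cc(CNCc2cccnc2)ccc1OCc1ccc(Cl)nc1`) differs from compound 3 by (pyridin-3-yl)methyl in place of 1H-1,2,4-triazol-3-yl on an amine nitrogen, which puts (pyridin-3-yl)methyl in place of 1H-1,2,4-triazol-3-yl on an amine nitrogen. Among the measured compounds shown here, the one measured step that bears on this change is a 1.2-fold lower number from compound 1 to compound 3 (0.10 log units; within the scatter), which also swaps the group on an amine nitrogen. No step beyond the scatter is therefore expected in this assay, and no direction can be favoured. The estimated step is a 1.2-fold lower number from compound 3 to compound 4 (0.06 log units; within the scatter). Compound 4 is expected at about 60000 nM, within an estimated range of 25000 nM to 130000 nM.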

Compound 4, half-maximal effective concentration: 5000 nM
For compound 4 the middle estimate is 12-fold (1.08 log units) above the measured one; measured number outside the range, below it.
By their numbers in this assay, from the lowest: compound 4; then compounds 3 and 1 (each within the scatter of the next).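

In this assay, among the compounds shown here, the group on this amine nitrogen can clearly change the number: (pyridin-3-yl)methyl in place of 1H-1,2,4-triazol-3-yl gives a 14-fold lower number from compound 3 to compound 4 (1.14 log units; beyond the scatter), whereas the one earlier step stayed within the scatter. Pyridin-3-yl in place of ((1-methyl-1H-tetrazol-5-yl)sulfanyl)methyl gives a large step in the same direction, a 17-fold lower number from compound 1 to compound 4 (1.24 log units; beyond the scatter). Nothing available explains this difference. Still open, from the compounds shown here alone, is whether the step comes from the pyridine ring or from the methyl link. A plain benzyl group or a longer chain ending in pyridin-3-yl would help separate the two.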